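This account rests on a few compounds, and the source may have more. Where it says the series, first, only, none or still open, it means among the compounds named here.

In a functional assay on HepG2 cells (Homo sapiens) for inhibition, read by MTT assay, with a stated time of 24 h (a higher number here means a weaker inhibitor of growth, a lower number a stronger inhibitor of growth), compound 1 `COc1cccc(C(=O)n2c(-c3cn(C)c4ccc(OC)cc34)nc3ccccc32)c1` gives 11700 nM, compound 2 `COc1ccc2c(c1)c(-c1nc3ccccc3n1C(=O)c1cccc(Br)c1)cn2C` gives 51300 nM and compound 3 `COc1cccc(C(=O)n2c(-c3cn(C)c4ccc(Br)cc34)nc3ccccc32)c1` gives 17800 nM. Compound 3 lies within the scatter of compound 1, and its number is lower than that of compound 2, beyond the scatter. Compound 4 `Cn1cc(-c2nc3ccccc3n2C(=O)c2cccc(Br)c2)c2cc(Br)ccc21` differs from compound 3 by bromo in place of methoxy on an aromatic carbon, the change 3-methoxyphenyl to 3-bromophenyl. Within the data shown here, the same change gave a 4.4-fold higher number from compound 1 to compound 2 (0.64 log units; beyond the scatter), the closest precedent. The exchange elsewhere on the shared core gave a 1.5-fold higher number from compound 1 to compound 3 (0.18 log units; within the scatter), which bears less directly. A step of similar size to that from compound 1 to compound 2 is therefore expected in this assay, towards a higher number. The expected step is a 3.7-fold higher number from compound 3 to compound 4 (0.56 log units; beyond the scatter). Compound 4 is estimated at 65000 nM, with an expected range of 28000 nM to 150000 nM.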

Compound 4, concentration for 50% growth inhibition: 67300 nM
Compound 4: middle estimate off by 1.0-fold (0.02 log units), on the low side, within the range that was stated.
By their numbers in this assay, from the lowest: compounds 1 and 3 (each within the scatter of the next); then compounds 2 and 4 (each within the scatter of the next).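

The change from 3-methoxyphenyl to 3-bromophenyl, previously seen on one core only, recurs with a 3.8-fold higher number from compound 3 to compound 4 (0.58 log units; beyond the scatter) in this assay. Its size holds whether methoxy or bromo stands at the other place on the shared core: the same change on two cores in this assay, a 4.4-fold higher number (0.64 log units; beyond the scatter) from compound 1 to compound 2 and a 3.8-fold higher number (0.58 log units; beyond the scatter) from compound 3 to compound 4, 1.2-fold (0.06 log units) apart, within the scatter of two such steps The exchange at that other place also stays small with 3-bromophenyl present, at a 1.3-fold higher number from compound 2 to compound 4 (0.12 log units; within the scatter): the same change on two cores in this assay, a 1.5-fold higher number (0.18 log units; within the scatter) from compound 1 to compound 3 and a 1.3-fold higher number (0.12 log units; within the scatter) from compound 2 to compound 4, 1.2-fold (0.06 log units) apart, within the scatter of two such steps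

Only methoxy and bromo are shown at either place, so the effect of an amine or a carboxylic acid on that aromatic carbon remains open. Also open, on these data alone, is whether the two places would still act separately with such groups.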